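The compounds below may be only part of what the source reports. "The series", "measured", "known", "first", "only" and "open" are said of these compounds alone.

Compound 1 `COc1cc(-c2cc(C(=O)/C=C/c3ccc(C)cc3)nc3cc(-c4ccccc4)nn23)cc(OC)c1OC` gives 20000 nM in a functional assay on A549 cells (Homo sapiens) for antiproliferative activity, read by MTT assay, with a stated time of 24 h; a lower number here means a stronger inhibitor, a higher number a weaker inhibitor. That is the smallest of the three numbers shown, but the distinction carries no weight: compound 3 `COc1cc(C(=O)/C=C/c2cc(-c3cc(OC)c(OC)c(OC)c3)n3nc(-c4ccccc4)cc3n2)cc(OC)c1OC` at 20500 nM and compound 2 `COc1ccc(-c2cc(C(=O)/C=C/c3ccc(C)cc3)nc3cc(-c4ccccc4)nn23)cc1OC` at 22200 nM both sit within the scatter of compound 1. Among the compounds with values here, the only measured step, a 1.1-fold higher number from compound 1 to compound 2 (0.05 log units; within the scatter), removes a methoxy from an aromatic carbon and leaves the number essentially unchanged. Compound 4 `COc1cc(-c2cc(C(=O)/C=C/c3ccccc3)nc3cc(-c4ccccc4)nn23)cc(OC)c1OC` differs from compound 1 by hydrogen in place of methyl on an aromatic carbon. Within the data shown here, no measured step touches the 2-phenylethenyl end directly, yet because a 1.1-fold higher number from compound 1 to compound 2 (0.05 log units; within the scatter) stayed within the scatter for a comparably small removal, no step beyond the scatter is expected in this assay. Compound 4 is therefore estimated at 20000 nM, with a range of 9000 nM to 45000 nM, an expected step of no change at the digits printed from compound 1 to compound 4 (within the scatter).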

Compound 4, half-maximal inhibitory concentration: 18000 nM
The estimate for compound 4 lay 1.1-fold (0.05 log units) above the measured number; low and high end bracket the measured number.
By their numbers in this assay, from the lowest: compounds 4, 1, 3 and 2 (each within the scatter of the next).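

In this assay, within the data shown here, replacing the methyl of the 4-methylphenyl group with hydrogen gives a 1.1-fold lower number from compound 1 to compound 4 (0.05 log units; within the scatter) and so adds a measured step at this end of the molecule, where the only earlier step lay at a methoxy. The methyl, para to a large group, can therefore be removed without a change beyond the scatter. Nothing measured here accounts for this result. As far as these compounds go, whether an amine, a carboxylic acid or a longer chain at this place would move the number stays open. So does whether any change on this ring reaches beyond the scatter.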